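This account rests on a few compounds, and the source may have more. Where it says the series, first, only, none or still open, it means among the compounds named here.

Compound 1 `COc1ccc(C(c2ccccc2O)c2cccc3ccccc23)c(OC)c1OC` carries a 2-hydroxyphenyl on the saturated chain carbon bound to two aromatic carbons of the shared core. In a functional assay on HCT-116 cells (Homo sapiens) for inhibition, read by sulforhodamine B assay, with a stated time of 48 h (a lower number here means a stronger inhibitor, a higher number a weaker inhibitor), compound 1 reaches only the limit of the measurement, giving > 20000 nM, so no number is known for it. Compound 2 `COc1ccc(C(O)(C/C=C\c2ccccc2)c2cccc3ccccc23)c(OC)c1OC` likewise returns only a limit, > 20000 nM, in this assay. For the measured compounds named here, compound 3 `COc1ccc(/C(=N/O)c2cccc3ccccc23)c(OC)c1OC` is the one member of the set with a measured number, 5880 nM in this assay. Going by the values given here, compound 1 thus stands at the limit of > 20000 nM in this assay, at which 2 of the 3 values shown sit, and the set offers no measured step between two numbers from which to read the effect of a single change. Compound 4 `COc1ccc(C(c2ccc(O)cc2)c2cccc3ccccc23)c(OC)c1OC` differs from compound 1 in one place: 4-hydroxyphenyl in place of 2-hydroxyphenyl on a saturated chain carbon bound to two aromatic carbons. Among the compounds with values here, with no comparable step measured, the change is expected to move the value little beyond the scatter of this assay. The step of a number no higher from compound 1 to compound 4 (the limit leaves the size open) is estimated as small, with no clear direction. Compound 4 is therefore expected to give about 20000 nM, between 6000 nM and 60000 nM, with a real chance that this assay again reports only a limit.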

Compound 4, half-maximal inhibitory concentration: 16000 nM
Estimate against measurement, compound 4: 1.3-fold (0.10 log units) above; the range from low to high includes it.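

Compound 4 gives a measured number in this assay, so 4-hydroxyphenyl on the saturated chain carbon bound to two aromatic carbons brings this pair within the range of the read-out, and the change amounts to an at least 1.2-fold lower number from compound 1 to compound 4 (0.09 log units; that floor lies within the scatter). That step has only a floor, so it shows that the change does not raise the number but cannot say how large it is. Limits still mark much of the set: the limit of > 20000 nM in this assay, at which 2 of the 4 values shown sit.

The compounds shown leave open how far the true value of compound 1 lies from that of compound 4, and so whether the two hydroxyphenyl groups differ at all. They also leave open what a plain phenyl, a 4-methoxyphenyl or a 4-aminophenyl would give at this place on the shared core.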